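Ketone and oxime pairs on a shared core

A few compounds are considered here, and "the series" means these few. Any claim that something is new, unique, unknown or untested is made for them only; others in the source may bear on it.

Measured compounds:
compound 1 `COc1ccc(C(=O)CSc2nc3c([nH]2)c(=O)n(C)c(=O)n3C)cc1` — 8100 nM
compound 2 `Cn1c(=O)c2[nH]c(SCC(=O)c3ccc(Cl)cc3)nc2n(C)c1=O` — 9900 nM
compound 3 `COc1ccc(/C(CSc2nc3c([nH]2)c(=O)n(C)c(=O)n3C)=N\O)cc1` — 1700 nM

In a functional assay on HT-29 cells (Homo sapiens) for inhibition, read by MTT assay, with a stated time of 48 h (a lower number here means a stronger inhibitor, a higher number a weaker inhibitor), compound 1 gives 8100 nM and compound 2 gives 9900 nM. The change between them is chloro in place of methoxy on an aromatic carbon, and the step is a 1.2-fold higher number from compound 1 to compound 2 (0.09 log units; within the scatter). Compound 3 gives 1700 nM; the difference between its core and that of compound 1 is not broken down here.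

Compound 4 `Cn1c(=O)c2[nH]c(SC/C(=N/O)c3ccc(Cl)cc3)nc2n(C)c1=O` is not yet measured. It stands to compound 3 as compound 2 stands to compound 1: the change is chloro in place of methoxy on an aromatic carbon, the same change at the same place. Because the earlier step was a 1.2-fold higher number from compound 1 to compound 2 (0.09 log units; within the scatter), a step of about that size is expected here, a 1.2-fold higher number from compound 3 to compound 4 (0.07 log units; within the scatter). Compound 4 is therefore estimated at 2000 nM, with a likely range from 900 nM to 4500 nM.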

Compound 4, half-maximal inhibitory concentration: 1200 nM
Compound 4: middle estimate off by 1.7-fold (0.22 log units), on the high side; the range from low to high includes it.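

In this assay, among these compounds, chloro in place of methoxy on the oxime pair gives a 1.4-fold lower number from compound 3 to compound 4 (0.15 log units; within the scatter), and this step agrees with the one on the ketone pair: the same change on two cores in this assay, a 1.2-fold higher number (0.09 log units; within the scatter) from compound 1 to compound 2 and a 1.4-fold lower number (0.15 log units; within the scatter) from compound 3 to compound 4, 1.7-fold (0.24 log units) apart, within the scatter of two such steps. The change therefore carries between these two cores without a detectable shift in either pair. Among the compounds shown here, with only two pairs and both steps within the scatter, this shows no real effect of the change and does not show that the agreement would hold on another core or for a change that moves the number more.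

Only methoxy and chloro are shown on the aromatic ring, leaving open an amine, a carboxylic acid or a nitrile at that place. On these data alone, a longer chain to the sulfur and a methyl ether of the oxime also remain open.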